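Swapping a thiazolyl group on a mouse exposure series

A few compounds are considered here, and "the series" means these few. Any claim that something is new, unique, unknown or untested is made for them only; others in the source may bear on it.

Three related compounds have been measured in an ADME assay on the whole organism (plasma, strain 129/SvEvBrd x C57BL/6) for pharmacokinetics, with Mus musculus as the target, at a dose of 10 mg/kg by the oral route; a lower number here means less compound in the circulation, a higher number more compound in the circulation at the dose given. There, compound 1 (`CC(=O)c1nc([C@@H](O)[C@H](O)[C@H](O)CO)c(C)[nH]1`) gives 2640 ng.h/mL, compound 2 (`CCc1[nH]c(C(C)=O)nc1[C@@H](O)[C@H](O)[C@H](O)CO`) gives 1650 ng.h/mL and compound 3 (`OC[C@@H](O)[C@@H](O)[C@H](O)c1c[nH]c(-c2cscn2)n1`) gives 1570 ng.h/mL. Compound 3 therefore lies within the usual scatter of both others, and the three cannot be ranked.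

Compound 4 (`Cn1cnc(-c2nc([C@@H](O)[C@H](O)[C@H](O)CO)c[nH]2)c1`) carries 1-methyl-1H-imidazol-4-yl in place of the 1,3-thiazol-4-yl of compound 3, on an aromatic carbon of the shared core: 1-methyl-1H-imidazol-4-yl in place of 1,3-thiazol-4-yl on an aromatic carbon.

For the measured compounds named here, no measured step covers this swap. The only one available, a 1.6-fold lower number from compound 1 to compound 2 (0.20 log units; within the scatter), places methyl on a saturated chain carbon rather than changing this aromatic group, so it offers only indirect guidance. It does show one small edit leaving this assay within the scatter, and all three values sit close together. No shift beyond the scatter is therefore expected, and the expected change is a 1.0-fold lower number from compound 3 to compound 4 (0.02 log units; within the scatter). For compound 4 the estimated value is 1500 ng.h/mL, with an expected range from 650 ng.h/mL to 3300 ng.h/mL.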

Compound 4, area under the concentration-time curve: 698 ng.h/mL
For compound 4 the middle estimate is 2.1-fold (0.33 log units) above the measured one; measured number inside the range.
By their numbers in this assay, from the lowest: compound 4; then compounds 3, 2 and 1 (each within the scatter of the next).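

On this aromatic carbon of the shared core, 1-methyl-1H-imidazol-4-yl in place of 1,3-thiazol-4-yl gives in this assay a 2.2-fold lower number from compound 3 to compound 4 (0.35 log units; beyond the scatter), the only step shown that lies beyond the scatter. The group at this place can therefore change the exposure, even though both groups are five-membered aromatic rings with 2 hetero atoms and the same counts of hydrogen-bond donors and acceptors. Nothing measured here explains the drop.

The compounds shown leave open whether the change in ring atoms or the added methyl accounts for the step, a question that the same ring without its methyl, a plain imidazolyl group, could help separate. From the compounds shown here alone, how a six-membered ring such as pyridinyl, or a simple amine, would behave at this place also remains open.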